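Removing the chlorine from compound 1

The source may hold more compounds than are shown below. What is called first, only, known or untested is meant among the compounds shown, and "the series" means these compounds.

Results in a functional assay on MDA-MB-231 cells (Homo sapiens) for antiproliferative activity, read by MTT assay, with a stated time of 48 h (on this read-out lower numbers stand for stronger inhibition and higher numbers for weaker inhibition), so far:
Compound 1 `COC(=O)/C(=C/c1ccccc1)CN1C(=O)[C@@H](OC)[C@H]1c1cccc(Cl)c1` has no result reported
Compound 2 `CCOC(=O)/C(=C/c1ccccc1)CN1C(=O)[C@@H](OC)[C@H]1c1cccc([N+](=O)[O-])c1` gives 14400 nM
Compound 3 `CCOC(=O)/C(=C/c1ccccc1)CN1C(=O)[C@@H](OC)[C@H]1c1ccccc1Br` gives 6860 nM

Compound 1 has no place on this scale, as no result was reported for it and there is no number to start from. Compound 4 `COC(=O)/C(=C/c1ccccc1)CN1C(=O)[C@@H](OC)[C@H]1c1ccccc1` is compound 1 with a single change, (hydrogen in place of chloro on an aromatic carbon), that is, hydrogen in place of chloro on an aromatic carbon, which turns 3-chlorophenyl to phenyl.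

Among the compounds with values here, the only measured step is a 2.1-fold lower number from compound 2 to compound 3 (0.32 log units; beyond the scatter). It swaps one substituted phenyl group for another in compounds carrying an ethyl ester, whereas compound 1 and compound 4 carry a methyl ester, and it does not remove a chloro group. With no starting number, no size or direction of step can be expected in this assay. The estimate can lean only on the general level set by compound 2 at 14400 nM and compound 3 at 6860 nM, and its range is kept wide. For compound 4 the expected value is 10000 nM, with an estimated range from 3000 nM to 30000 nM.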

Compound 4, half-maximal inhibitory concentration: 11100 nM
Compound 4: middle estimate off by 1.1-fold (0.05 log units), on the low side; measured number inside the range.
By their numbers in this assay, from the lowest: compounds 3, 4 and 2 (each within the scatter of the next, the first and the last beyond it).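

Compound 4 cannot be set against compound 1, since compound 1 offers no number to compare in this assay, so no step can be read. On these data alone, what removing the chloro group does to the number stays open. No evidence here bears on the result for compound 4.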